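The source may report more compounds than this note shows. Statements on the series, on what has been measured and on what is new or still open speak of the compounds shown alone.

Compound 1 `CCOc1ccccc1NCn1nc(-c2ccc3c(c2)OCCO3)oc1=S` gives 5280 nM in a functional assay, with a stated time of 6 min (on this read-out lower numbers stand for stronger inhibition and higher numbers for weaker inhibition), the lowest of the three measured numbers. Compound 3 `S=c1oc(-c2ccc3c(c2)OCCO3)nn1CNc1ccccc1Cl` gives 7230 nM in this assay, and compound 2 `S=c1oc(-c2ccc3c(c2)OCCO3)nn1CNC1CCCCC1` gives 18400 nM, so the step of a 1.4-fold higher number from compound 1 to compound 3 (0.14 log units; within the scatter) stays within the scatter while a 3.5-fold higher number from compound 1 to compound 2 (0.54 log units; beyond the scatter) lies beyond it.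

Compound 4 `Cc1ccccc1NCn1nc(-c2ccc3c(c2)OCCO3)oc1=S` differs from compound 1 by methyl in place of ethoxy on an aromatic carbon. Within the data shown here, the closest precedent is the exchange of one group on the same aromatic carbon, a 1.4-fold higher number from compound 1 to compound 3 (0.14 log units; within the scatter), which barely moved the number; only replacing the whole ring, a 3.5-fold higher number from compound 1 to compound 2 (0.54 log units; beyond the scatter), gave a modest rise. A small step, if any, is therefore expected for compound 4, estimated as a 1.2-fold higher number from compound 1 to compound 4 (0.09 log units; within the scatter), with a value of about 6500 nM, likely between 3000 nM and 14000 nM.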

Compound 4, half-maximal inhibitory concentration: 3450 nM
Estimate against measurement, compound 4: 1.9-fold (0.28 log units) above; low and high end bracket the measured number.
By their numbers in this assay, from the lowest: compounds 4, 1 and 3 (each within the scatter of the next, the first and the last beyond it); then compound 2.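

In this assay, methyl and ethoxy on this aromatic carbon cannot be told apart (a 1.5-fold lower number from compound 1 to compound 4 (0.18 log units; within the scatter)), so the extra heavy atoms of ethoxy are not needed here. Methyl and chloro do separate, though modestly (a 2.1-fold lower number from compound 3 to compound 4 (0.32 log units; beyond the scatter)), the first exchange on this carbon to pass the scatter. Among the steps so far, 2-methylphenyl in place of cyclohexyl gives the largest (a 5.3-fold lower number from compound 2 to compound 4 (0.73 log units; beyond the scatter)).

Nothing measured here explains these differences. Still open, going by these compounds, is how a fluoro, a hydroxyl or a longer chain such as propyl on this carbon would read.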